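Thiocarbamate series: swapping the amine on the thiocarbonyl

A few compounds are considered here, and "the series" means these few. Any claim that something is new, unique, unknown or untested is made for them only; others in the source may bear on it.

Of the compounds shown here, three have been measured in a functional assay on HeLa cells (Homo sapiens) for antiproliferative activity, read by MTT assay, with a stated time of 72 h; on this read-out higher numbers stand for weaker inhibition and lower numbers for stronger inhibition. Compound 1 `CCN(CC)C(=S)SCC1=CCOC1=O` gives 1390 nM in this assay. Compound 3 `O=C1OCC=C1CSC(=S)N1CCOCC1` gives 2430 nM, a number that sits within the usual scatter of that of compound 1, so the two cannot be told apart. Compound 2 `O=C1CC2(CO1)CSC(=S)N2c1ccccc1`, built on a different core, gives 18000 nM, a higher number that lies well beyond the scatter of compound 1. Among the measured compounds shown here, compound 1 therefore marks the low end of the numbers so far, shared with compound 3.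

The next compound keeps the core of compound 1 and changes only the amine on the thiocarbonyl: compound 4 `CC(C)NC(=S)SCC1=CCOC1=O` carries isopropylamino in place of diethylamino on a thiocarbonyl carbon. For the measured compounds named here, no pair of measured compounds shows this change, so its size is unknown here; compounds 1 and 3, which differ at the same position, sit within the scatter of each other. On that basis the step of a 1.4-fold higher number from compound 1 to compound 4 (0.16 log units; within the scatter) is expected to be small, if anything towards a slightly higher number. Compound 4 is expected to give 2000 nM in this assay, with a range of 700 nM to 6000 nM.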

Compound 4, half-maximal inhibitory concentration: 137000 nM
Compound 4: middle estimate off by 69-fold (1.84 log units), on the low side; measured number outside the range, above it.
By their numbers in this assay, from the lowest: compounds 1 and 3 (each within the scatter of the next); then compound 2; then compound 4.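

In this assay the amine on the thiocarbonyl carbon turns out to be a sensitive position: isopropylamino in place of diethylamino gives a large step (a 99-fold higher number from compound 1 to compound 4 (1.99 log units; beyond the scatter)), although compounds 1 and 3, which differ at the same position, lie within the scatter of each other. The entering group carries 1 hydrogen-bond donor where diethylamino and the morpholine ring of compound 3 carry none, so the amine's identity here can matter greatly. No measurement at hand accounts for the size of this step.

From the compounds shown here alone, whether the amide-like hydrogen on nitrogen or the isopropyl group itself goes with the higher number stays open. Ethylamino and N-methyl-isopropylamino on the core of compound 1 would separate the two.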